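The source may hold more compounds than are shown below. What is called first, only, known or untested is meant among the compounds shown, and "the series" means these compounds.

Of the compounds shown here, two of a shared core have been tested so far. Compound 1 `Fc1ccc(-c2cn3ccnc3c(-c3ccc4ncn(C5CCCCC5)c4c3)n2)cc1` and compound 2 `Brc1ccc(-c2cn3ccnc3c(-c3ccc4ncn(C5CCCCC5)c4c3)n2)cc1` differ only at one aromatic carbon, where bromo replaces fluoro. In a functional assay on RPMI-8226 cells (Homo sapiens) for inhibition, read by sulforhodamine B assay, with a stated time of 48 h, tested at 10 uM (on this read-out lower numbers stand for less inhibition and higher numbers for more inhibition at the one concentration tested (going by the name of the read-out)), compound 1 gives 50.1%, and compound 2 gives 32.1%, a change described by a number 18 percentage points lower from compound 1 to compound 2 (beyond the scatter). Among the compounds with values here, compound 2 thus stands lowest of the two numbers, with compound 1 its only neighbour.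

Compound 3 `Fc1ccccc1-c1cn2ccnc2c(-c2ccc3ncn(C4CCCCC4)c3c2)n1` now follows from compound 2 by the change (2-fluorophenyl in place of 4-bromophenyl on an aromatic carbon). Within the data shown here, the single measured step bears on it only in part: it shows that fluoro rather than bromo went with a modest rise, but nothing measured tells how a 2-fluorophenyl compares with the 4-fluorophenyl of compound 1. The expectation is therefore a modest upward step, a number 12.9 percentage points higher from compound 2 to compound 3 (beyond the scatter), with wide uncertainty. Compound 3 is estimated at 45%, expected to fall between 25% and 65%.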

Compound 3, a percentage reported as inhibition, at one concentration (the size of the read-out at that concentration, not a potency): 42.4%
Beside the measured number, compound 3's estimate is 2.6 percentage points above it, and the stated range covers the measured number.
By their numbers in this assay, from the lowest: compound 2; then compounds 3 and 1 (each within the scatter of the next).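

In this assay, moving the fluoro group to the 2-position of the phenyl ring and replacing the 4-bromophenyl gives a number 10.3 percentage points higher from compound 2 to compound 3 (beyond the scatter), so a second fluorophenyl compound now stands clear of the bromo compound. The placement of fluorine on this aryl group makes no readable difference, since the change gives a number 7.7 percentage points lower from compound 1 to compound 3 (within the scatter), and the 2-fluorophenyl and 4-fluorophenyl compounds cannot be told apart here. Nothing available explains these numbers or connects them to a property of either group.

The compounds shown leave open whether a plain phenyl would read with the two fluorophenyl compounds or with compound 2. They also leave open how this position would respond to a phenyl carrying an amine or a carboxylic acid.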